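A few compounds are considered here, and "the series" means these few. Any claim that something is new, unique, unknown or untested is made for them only; others in the source may bear on it.

Compound 1 `COc1ccc(-n2nc(C(N)=O)nc2-c2cc(OC)c(OC)c(OC)c2)cc1` gives 64% in a functional assay on the whole organism for inhibition, with Rattus norvegicus as the target, read by paw edema, with stated times of 30 min and 5 h, at a dose of 0.28 mmol/kg by the oral route; on this read-out lower numbers stand for less inhibition and higher numbers for more inhibition at the one dose given (going by the name of the read-out). Compound 2 `COc1ccc(-n2nc(C(=O)Nc3ccccc3C)nc2-c2cc(OC)c(OC)c(OC)c2)cc1` gives 47% and stands lowest of the two numbers, with the step of a number 17 percentage points lower from compound 1 to compound 2 (beyond the scatter) lying beyond the scatter. Compound 3 `COc1ccc(-n2nc(C(=O)Nc3ccc(O)cc3)nc2-c2cc(OC)c(OC)c(OC)c2)cc1` carries the change (4-hydroxyphenyl in place of 2-methylphenyl on an amide-type nitrogen). Going by the values given here, no measured step exchanges one aryl group for another on this amide-type nitrogen; the only step known, from hydrogen to an aryl group, does not bear on it. No step beyond the scatter is therefore expected, the estimated change being a number 3 percentage points higher from compound 2 to compound 3 (within the scatter). Compound 3 is expected at 50%, within 30% to 70%.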

Compound 3, a percentage reported as inhibition, in the whole organism at one dose (the size of the read-out at that dose, not a potency): 27%
For compound 3 the middle estimate is 23 percentage points above the measured one; the measured number lies below the stated range.
By their numbers in this assay, from the lowest: compound 3; then compound 2; then compound 1.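

In this assay, the identity of the aryl group on the amide-type nitrogen matters, not only its presence: 4-hydroxyphenyl in place of 2-methylphenyl gives a number 20 percentage points lower from compound 2 to compound 3 (beyond the scatter). Against hydrogen on that nitrogen, 4-hydroxyphenyl gives a number 37 percentage points lower from compound 1 to compound 3 (beyond the scatter), so neither aryl group shown matches the unsubstituted amide. No evidence at hand bears on the cause of these steps. From the compounds shown here alone, whether the loss of the methyl group or the arrival of the hydroxyl group drives the step stays open. So does the effect of an amine or a carboxylic acid on the phenyl ring, or of a longer chain in place of the aryl group.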